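This account rests on a few compounds, and the source may have more. Where it says the series, first, only, none or still open, it means among the compounds named here.

Measured in an ADME assay on MT4 cells (Homo sapiens) for cytotoxicity, read by XTT assay, with a stated time of 5 days; a lower number here means that less compound is tolerated, a higher number that more compound is tolerated:

Compound 1 `C=CCNC(=O)[C@@H](NC(=O)[C@@](O)(CCCN(Cc1ccc(Br)cc1)NC(=O)[C@@H](NC(=O)OC)C(C)(C)C)Cc1ccc(Br)cc1)C(C)C`: 22000 nM
Compound 2 `C=CCNC(=O)[C@@H](NC(=O)[C@@](O)(CCCN(Cc1ccc(Br)cc1)NC(=O)[C@@H](NC(=O)OC)C(C)(C)C)Cc1ccc(C=C)cc1)C(C)(C)C`: 44000 nM

Only these two compounds have been measured so far. Compound 2, at 44000 nM, cannot be told apart from compound 1, at 22000 nM, as the two values lie within the usual scatter of repeated measurements. Both show that the cells tolerate these compounds up to high concentrations.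

Compound 3 `C=CCNC(=O)[C@@H](NC(=O)[C@@](O)(CCCN(Cc1ccc(Br)cc1)NC(=O)[C@@H](NC(=O)OC)C(C)(C)C)Cc1ccc(C=C)cc1)C(C)C` has not yet been measured in this assay. It departs from compound 2 in a single place, hydrogen in place of methyl on a saturated chain carbon bound to three saturated chain carbons, so that tert-butyl becomes isopropyl. For the measured compounds named here, no measured pair shows this change alone, so the data give no direct size for it. The expectation therefore rests on the narrow spread between compound 1 at 22000 nM and compound 2 at 44000 nM, and no shift beyond the scatter is foreseen in either direction. The expected change is a 1.3-fold lower number from compound 2 to compound 3 (0.10 log units; within the scatter), which is estimated to stay within the scatter. The estimate for compound 3 is 35000 nM, with an expected range from 16000 nM to 75000 nM.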

Compound 3, half-maximal cytotoxic concentration: 25000 nM
Compound 3: the middle estimate sits 1.4-fold (0.15 log units) above what was measured; measured number inside the range.
By their numbers in this assay, from the lowest: compounds 1, 3 and 2 (each within the scatter of the next).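

In this assay, the change from tert-butyl to isopropyl, hydrogen in place of methyl on a saturated chain carbon bound to three saturated chain carbons, now has a direct reading of its own: a 1.8-fold lower number from compound 2 to compound 3 (0.25 log units; within the scatter). For the compounds shown here, compound 3 also gives the first single-place reading for vinyl in place of bromo on an aromatic carbon, a 1.1-fold higher number from compound 1 to compound 3 (0.06 log units; within the scatter), so neither change, taken alone, separates the compounds it links in this cell tolerance read-out. No independent measurement bears on these results.

From the compounds shown here alone, each change is read once, on a single background, so it remains open whether either would behave the same way with the other group altered. Going by these compounds, it also remains open what an amine or a carboxylic acid on that aromatic carbon, or a longer chain in place of isopropyl, would give in this assay.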